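The compounds below may be only part of what the source reports. "The series", "measured", "known", "first", "only" and "open" are said of these compounds alone.

In a functional assay on PC-3 cells (Homo sapiens) for cytotoxicity (a higher number here means that more compound is needed for the effect, a lower number that less compound is needed), compound 1 `COC1=C(C)C(=O)/C(=C(O)/C=C/c2ccccc2C)C(=O)C1(C)C` gives 9 ug/mL and stands level with compound 2 `COC1=C(C)C(=O)/C(=C(O)/C=C/c2cccc3ccccc23)C(=O)C1(C)C` at 9 ug/mL within the usual scatter. Compound 3 `COC1=C(C)C(=O)/C(=C(O)/C=C/c2cccs2)C(=O)C1(C)C` has not yet been measured. It carries thiophen-2-yl in place of 2-methylphenyl on a double-bonded chain carbon bound to a double-bonded chain carbon. For the measured compounds named here, no measured pair of compounds differing in one place shows what such a change does, so the data give no direct size for it. In this assay no step beyond the scatter is expected, and neither direction is favoured. This expectation rests only on compound 1 at 9 ug/mL and compound 2 at 9 ug/mL as the values at hand. The estimated step of a 1.1-fold higher number from compound 1 to compound 3 (0.05 log units; within the scatter) is therefore expected to be small. For compound 3 the expected value is 10 ug/mL with an estimated range from 4 ug/mL to 25 ug/mL in this measurement.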

Compound 3, concentration for half-maximal effect: 18.2 ug/mL
Compound 3: the middle estimate sits 1.8-fold (0.26 log units) below what was measured, within the range that was stated.
By their numbers in this assay, from the lowest: compounds 1 and 2 (each within the scatter of the next); then compound 3.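

In this assay, for the compounds shown here, replacing 2-methylphenyl with thiophen-2-yl on a double-bonded chain carbon bound to a double-bonded chain carbon gives a 2.0-fold higher number from compound 1 to compound 3 (0.31 log units; beyond the scatter) and provides the first measured step for a change at this place. The place is therefore not indifferent to the group it carries, something the level values of compound 1 and compound 2 could not show, although this modest step rests on a single pair. No measurement shown here accounts for the step.

The compounds shown leave open whether the five-membered ring or its sulfur atom matters more, a question that furan-2-yl or unsubstituted phenyl at the same place could address. As far as these compounds go, how an amine or a carboxylic acid on that aromatic ring would shift the number also remains open.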